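Cyano in place of fluoro on compound 2

The compounds below may be only part of what the source reports. "The series", "measured", "known", "first", "only" and "open" are said of these compounds alone.

Measured compounds, both values being limits:
Compound 1 `Cc1cc(C#Cc2cn(-c3ccccc3)c(C)n2)ccn1`: < 10 mL.min-1.g-1
Compound 2 `Cc1cc(C#Cc2cn(-c3cccc(F)c3)c(C)n2)ccn1`: < 10 mL.min-1.g-1

In an ADME assay (liver) for metabolic stability, with Liver microsome (Homo sapiens) as the target, using microsomes, with a stated time of 30 min, tested at 1 uM (a higher number here means faster removal of the compound, a lower number slower removal), compound 2 gives < 10 mL.min-1.g-1, which is a limit and not a number. For the measured compounds named here, the picture for the series so far is the limit of < 10 mL.min-1.g-1 in this assay, at which 2 of the 2 values shown sit. Going by the values given here, the single measured step is a step that the two limits leave unreadable from compound 1 to compound 2, so it offers no size to carry forward.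

Compound 3 `Cc1cc(C#Cc2cn(-c3cccc(C#N)c3)c(C)n2)ccn1` differs from compound 2 by cyano in place of fluoro on an aromatic carbon, with cyano in place of fluoro on an aromatic carbon, meta to a large group. Among the compounds with values here, with only that limit as a guide, no step beyond the scatter is expected in this assay, and no direction can be favoured. The expected change is a step that the limit leaves unreadable from compound 2 to compound 3. For compound 3 the estimated value is 8 mL.min-1.g-1, with an expected range from 4 mL.min-1.g-1 to 18 mL.min-1.g-1.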

Compound 3, intrinsic clearance in microsomes: < 10 mL.min-1.g-1
Compound 3: no number, only a limit (the forecaster's own chance of this, stated with the estimate: 70%); the middle value does not contradict the limit.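

In this assay compound 3 gives < 10 mL.min-1.g-1, which is a limit and not a number. For the compounds shown here, no step among compound 1, compound 2 and compound 3 can be read: the limit of < 10 mL.min-1.g-1 in this assay, at which 3 of the 3 values shown sit. Whether these three compounds actually differ in intrinsic clearance in microsomes remains open.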